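Cyano in place of methoxy on the core of compound 1

A few compounds are considered here, and "the series" means these few. Any claim that something is new, unique, unknown or untested is made for them only; others in the source may bear on it.

Measured so far:
compound 1 `COc1cccc(Cc2cnc(CCc3ccc(-c4ccccc4C(=O)O)cc3)[nH]2)c1` gives 4120 nM
compound 2 `CCCCc1cnc(C(Cc2ccc(-c3ccccc3C(=O)O)cc2)C(C)C)[nH]1` gives 4620 nM

In an in vitro functional assay on cells for agonist activity at Bombesin receptor subtype-3 (Homo sapiens), read by luminescence and calcium flux (on this read-out lower numbers stand for an effect already at smaller amounts and higher numbers for an effect only at larger amounts of compound), compound 1 stands at the lower of the two numbers shown, but the number of compound 2 lies within the scatter of it, so no order between the two can be read from the data. Compound 3 `N#Cc1cccc(Cc2cnc(CCc3ccc(-c4ccccc4C(=O)O)cc3)[nH]2)c1` has not yet been measured. It differs from compound 1 in one place: cyano in place of methoxy on an aromatic carbon. Among the compounds with values here, no measured pair carries this exchange, so there is no precedent for its size or direction. The step of a 1.1-fold lower number from compound 1 to compound 3 (0.06 log units; within the scatter) is expected to be small and of no clear direction, most likely staying within the scatter of repeated measurements. Compound 3 is therefore expected to give about 3600 nM, with a range of 1200 nM to 11000 nM.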

Compound 3, half-maximal effective concentration: 812 nM
The estimate for compound 3 lay 4.4-fold (0.65 log units) above the measured number; measured number outside the range, below it.
By their numbers in this assay, from the lowest: compound 3; then compounds 1 and 2 (each within the scatter of the next).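

In this assay, cyano in place of methoxy brings a 5.1-fold lower number from compound 1 to compound 3 (0.71 log units; beyond the scatter), the only step among the compounds shown and one that lies beyond the scatter. The aromatic carbon meta to a large group is therefore not indifferent to what it carries, even though the two groups match in heavy atoms and hydrogen-bond acceptors as counted under this exchange, so those counts do not separate them. No measurement at hand bears on the reason for this step.

As far as these compounds go, it remains open whether the step is particular to cyano, or whether a chlorine, a trifluoromethyl group, a primary amide or plain hydrogen on the same carbon would give a similar number. Also open, from the compounds shown here alone, is whether cyano on another carbon of that ring would keep the step.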